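Removing the methyl from compound 3

This account rests on a few compounds, and the source may have more. Where it says the series, first, only, none or still open, it means among the compounds named here.

In a functional assay, tested at 50 ug/mL (on this read-out lower numbers stand for a weaker effect and higher numbers for a stronger effect at the one concentration tested), compound 1, with the structure `O=S(=O)(CC1=NCCO1)c1n[nH]cc1-c1ccccc1`, gives 53.3%. Compound 2, with the structure `O=S(=O)(CC1=NCCS1)c1n[nH]cc1-c1ccc(Cl)cc1`, is recorded in this assay as "not active" (no number reported), so no number stands for it. Compound 3, with the structure `Cc1ccc(-c2c[nH]nc2S(=O)(=O)CC2=NCCS2)cc1`, is likewise recorded in this assay as "not active" (no number reported), and so compound 3 stands without a number, one of two compounds in this set for which no figure was reported. Only compound 1 carries a number in this assay.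

Compound 4 has the structure `O=S(=O)(CC1=NCCS1)c1n[nH]cc1-c1ccccc1` and has not yet been measured in this assay. It is reached from compound 3 by one change: hydrogen in place of methyl on an aromatic carbon. No step between two measured compounds of this kind is recorded, so the size of the step from compound 3 to compound 4 cannot be read from the numbers shown. Since compound 3 has no number, compound 4 is expected to be reported either as not active or with a modest figure. Compound 4 is estimated to give 25% in this assay, within a range from 0% to 55%, with a considerable chance that, like compound 3, no number at all is reported.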

Compound 4, a percentage reported as activity, at one concentration (the size of the read-out at that concentration, not a potency): "not active" (no number reported)
Compound 4: no number reported, and the estimate cannot be compared.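

In this assay, for the compounds shown here, compound 3 and compound 4 both stand without a number, so no step between them can be read. No evidence bears on this result. The compounds shown leave open whether the change from 4-methylphenyl to phenyl alters this read-out at all, since neither compound gives a figure to compare.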